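The source may hold more compounds than are shown below. What is called first, only, known or untested is meant among the compounds shown, and "the series" means these compounds.

Within the data shown here, in a functional assay on NCI-H520 cells (Homo sapiens) for cytotoxicity (a higher number here means a weaker inhibitor of growth, a lower number a stronger inhibitor of growth), compound 2 `COc1ccc(C2=C(c3ccc(SC)cc3)CC3CCCN3C2=O)cc1Br` gives 700 nM, the only exact number so far. Compound 3 `CSc1ccc(C2=C(c3ccc(O)c(O)c3)C(=O)N3CCCC3C2)cc1` has 3,4-dihydroxyphenyl in place of 3-bromo-4-methoxyphenyl on a double-bonded ring carbon. Among the measured compounds shown here, no measured pair shows this change directly. Compound 1 `COc1ccc(C2=C(c3cc(OC)c(OC)c(OC)c3)CC3CCCN3C2=O)cc1O`, which also carries a hydroxyl on a phenyl ring, gives > 100000 nM, a limit of the assay and not a number, and this single comparison hints at weaker growth inhibition with the new group. The expected change is a 7.1-fold higher number from compound 2 to compound 3 (0.85 log units; beyond the scatter), larger than the usual scatter but uncertain. Compound 3 is estimated at 5000 nM, with an expected range of 800 nM to 50000 nM.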

Compound 3, concentration for 50% growth inhibition: 60000 nM
Estimate against measurement, compound 3: 12-fold (1.08 log units) below, and the stated range ends below it.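

In this assay, among these compounds, putting 3,4-dihydroxyphenyl in place of 3-bromo-4-methoxyphenyl on this double-bonded ring carbon gives an 86-fold higher number from compound 2 to compound 3 (1.93 log units; beyond the scatter) and is the first direct reading of a change at this position. This single step swaps several features at once, so it cannot separate the loss of the bromine or the methoxy from the gain of the two hydroxyls. The measured number now lies near the end of the range that this assay can read: the limit of > 100000 nM in this assay, at which 1 of the 3 values shown sits.

Still open, from the compounds shown here alone, is whether a phenyl ring with one hydroxyl and the bromine kept would hold growth inhibition. Also open, going by these compounds, is how an amine on this ring would compare.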